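A few compounds are considered here, and "the series" means these few. Any claim that something is new, unique, unknown or untested is made for them only; others in the source may bear on it.

In a functional assay on MCF7 cells (Homo sapiens) for antiproliferative activity, read by MTT assay, with a stated time of 48 h (on this read-out lower numbers stand for stronger inhibition and higher numbers for weaker inhibition), compound 1 `Cc1cnc(Nc2ccc(C(C)C)cc2)nc1Nc1nc2ccccc2s1` is reported only as a limit, > 50000 nM. Compound 2 `Cc1ccc2nc(Nc3nc(Nc4ccc(S(C)(=O)=O)cc4)ncc3F)sc2c1` likewise returns only a limit, > 50000 nM. Going by the values given here, compound 3 `NS(=O)(=O)c1ccc(Nc2ncc(F)c(Nc3nc4ccc(Cl)cc4s3)n2)cc1` is the one member with a number, giving 8340 nM. Compound 1 therefore stands at the limit of > 50000 nM in this assay, at which 2 of the 3 values shown sit, with no number of its own to set beside compound 3.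

Compound 4 `Cc1cnc(Nc2cccc(F)c2)nc1Nc1nc2ccccc2s1` is yet to be measured in this assay. It differs from compound 1 by 3-fluorophenyl in place of 4-isopropylphenyl on a nitrogen on an aromatic ring. Among the compounds with values here, no step between measured compounds bears on this exchange, and the series holds no other pair that differs only at that ring. Compound 1 sits at a limit, and a limit leaves any step from it readable only as a gain or as none at all. The step of an at least 1.2-fold lower number from compound 1 to compound 4 (0.09 log units; that floor lies within the scatter) is expected to be small, at most a modest gain that may still sit within the scatter. Compound 4 is expected at about 40000 nM, within 8000 nM to 100000 nM. A repeated limit for compound 4 is expected to remain a real possibility.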

Compound 4, half-maximal inhibitory concentration: > 50000 nM
Compound 4: only a limit was reported; the forecaster's own chance of this, stated with the estimate: 55%; at least 1.2-fold (0.09 log units) between middle value and limit.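

Compound 1 and compound 4 both return only limits, so no step can be read between them: the limit of > 50000 nM in this assay, at which 3 of the 4 values shown sit.

The compounds shown leave open how 3-fluorophenyl and 4-isopropylphenyl compare on the shared core in this assay, where neither compound 1 nor compound 4 has a number of its own.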